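A few compounds are considered here, and "the series" means these few. Any claim that something is new, unique, unknown or untested is made for them only; others in the source may bear on it.

Measured compounds:
compound 1 `COc1ccc(N2C(=O)C(C)(C)c3cccnc32)cc1`, 0% in a functional assay on the whole organism with Rattus norvegicus as the target, at a dose of 25 mg/kg; a lower number here means less inhibition, a higher number more inhibition at the dose given (going by the name of the read-out)
compound 2 `CC1(C)C(=O)N(c2ccc(Cl)cc2)c2ncccc21`, 13%
compound 3 `CC1(C)C(=O)N(c2ccccc2)c2ncccc21`, 0%

Compound 3 sits level with compound 1, the two together at the lowest of the three numbers, while compound 2 stands apart: a number 13 percentage points lower from compound 2 to compound 3 (beyond the scatter). Compound 4 `CC1(C)C(=O)N(c2ccc(F)cc2)c2ncccc21` differs from compound 3 by fluoro in place of hydrogen on an aromatic carbon. Two measured steps change the same aromatic carbon: no change at the digits printed from compound 1 to compound 3 (within the scatter) and a number 13 percentage points lower from compound 2 to compound 3 (beyond the scatter). Only chloro there gave a reading beyond the scatter, methoxy and hydrogen gave none. Fluoro is a single small atom, so a step of a number 5 percentage points higher from compound 3 to compound 4 (within the scatter) is expected, at most modest. Compound 4 is therefore expected to give 5%, within 0% to 15%.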

Compound 4, a percentage reported as inhibition, in the whole organism at one dose (the size of the read-out at that dose, not a potency): 0%
Beside the measured number, compound 4's estimate is 5 percentage points above it; the measured number falls inside the stated range.
By their numbers in this assay, from the lowest: compounds 1, 3 and 4 (each within the scatter of the next); then compound 2.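

In this assay, fluoro on this aromatic carbon reads like hydrogen and methoxy (no change at the digits printed from compound 3 to compound 4 (within the scatter) and no change at the digits printed from compound 1 to compound 4 (within the scatter)) but not like chloro (a number 13 percentage points lower from compound 2 to compound 4 (beyond the scatter)). A halogen at this place is therefore not enough on its own to give a reading, and among the four groups shown, only chloro gives one beyond the scatter. Nothing available here explains why the two halogens part ways. As far as these compounds go, whether bromine, an amine or a carboxylic acid on this carbon would read like chloro or like fluoro stays open.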